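This account rests on a few compounds, and the source may have more. Where it says the series, first, only, none or still open, it means among the compounds named here.

Measured so far:
compound 1, `CCNC1=NS(=O)(=O)c2ccc(Cl)cc2N1`: in a functional assay on aorta (Rattus norvegicus) for inhibition (on this read-out higher numbers stand for an effect only at larger amounts of compound and lower numbers for an effect already at smaller amounts), compound 1 gives 54800 nM.
compound 2, `CC(C)NC1=NS(=O)(=O)c2ccc(Cl)cc2N1`: in this assay compound 2 gives 53400 nM.
compound 3, `CCNC1=NS(=O)(=O)c2cc(Cl)ccc2N1`: in this assay compound 3 gives 39900 nM.

Compound 1 and compound 2 differ by methyl in place of hydrogen on a saturated chain carbon bound to an amine nitrogen and a saturated chain carbon; this change made a 1.0-fold lower number from compound 1 to compound 2 (0.01 log units; within the scatter). Compound 3 has the same atoms as compound 1, joined differently; the difference between the two cores is not broken down here. All three values lie within the usual scatter of one another. Compound 4, `CCCNC1=NS(=O)(=O)c2cc(Cl)ccc2N1`, is not yet measured. It differs from compound 3 by methyl in place of hydrogen on a saturated chain carbon, two bonds along the chain from an amine nitrogen. This is the same kind of change as from compound 1 to compound 2, but not the same: there the entering carbon sits on a saturated chain carbon bound to an amine nitrogen and a saturated chain carbon, here on a saturated chain carbon, two bonds along the chain from an amine nitrogen. Because the earlier step gave a 1.0-fold lower number from compound 1 to compound 2 (0.01 log units; within the scatter), compound 4 is expected to show a 1.1-fold lower number from compound 3 to compound 4 (0.04 log units; within the scatter). Compound 4 is estimated in this assay at 36000 nM, between 15000 nM and 90000 nM.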

Compound 4, half-maximal effective concentration: 55500 nM
For compound 4 the middle estimate is 1.5-fold (0.19 log units) below the measured one, and the stated range covers the measured number.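

In this assay, going from ethylamino to propylamino gives a 1.4-fold higher number from compound 3 to compound 4 (0.14 log units; within the scatter). Set beside the earlier step, adding a methyl behaves alike on the two cores, with no gap that stands out from the usual variation between repeat measurements: the same change on two cores in this assay, a 1.0-fold lower number (0.01 log units; within the scatter) from compound 1 to compound 2 and a 1.4-fold higher number (0.14 log units; within the scatter) from compound 3 to compound 4, 1.4-fold (0.15 log units) apart, within the scatter of two such steps. Among the compounds shown here, this shows only that the change did little on either core; with both steps this small and just two pairs, it does not show that a real effect carries from one core to the other, and the methyl also enters at a different place on the chain in each pair.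

Still open, going by these compounds, is whether a longer chain, such as butylamino, would shift the number beyond the scatter on either core. The same question stands for a chain carrying an amine or a carboxylic acid.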